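The source may report more compounds than this note shows. Statements on the series, on what has been measured and on what is new or still open speak of the compounds shown alone.

In a functional assay on SK-BR-3 cells (Homo sapiens) for antiproliferative activity (on this read-out lower numbers stand for stronger inhibition and higher numbers for weaker inhibition), compound 1 `CC(=O)Oc1ccc(C(=O)Nc2cc3ccc(OCC4CCN(C)C4)c(C)c3oc2=O)cc1CC=C(C)C` gives 880 nM while compound 2 `CC(C)=CCc1cc(C(=O)Nc2cc3ccc(OCC4CCCNC4)c(C)c3oc2=O)ccc1O` gives 600 nM and compound 3 `CC(C)=CCc1cc(C(=O)Nc2cc3ccc(OCC4CCN(C)C4)c(C)c3oc2=O)ccc1O` gives 920 nM and these three numbers lie within the usual scatter of one another. For the measured compounds named here, compound 3 therefore stands level with both of its relatives, and the series so far offers no clear separation.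

Compound 4 `CCNCCCOc1ccc2cc(NC(=O)c3ccc(O)c(CC=C(C)C)c3)c(=O)oc2c1C` differs from compound 3 in a single group (2-(ethylamino)ethyl in place of 1-methylpyrrolidin-3-yl on a saturated chain carbon bound to an oxygen on an aromatic ring). In words, this is 2-(ethylamino)ethyl in place of 1-methylpyrrolidin-3-yl on a saturated chain carbon bound to an oxygen on an aromatic ring. Going by the values given here, the new group has no ring, and none of the measured compounds carries such an open chain here, so the data can guide the estimate only indirectly.

Among the compounds with values here, two measured steps bear on it. The closer one is a 1.5-fold higher number from compound 2 to compound 3 (0.19 log units; within the scatter) and it swaps one ring for another at this same place. The other is a 1.0-fold higher number from compound 1 to compound 3 (0.02 log units; within the scatter) and it concerns hydrogen in place of acetyl on a different oxygen. Neither step leaves the scatter, so no step beyond the scatter is expected in this assay here. The expected step is a 1.2-fold lower number from compound 3 to compound 4 (0.09 log units; within the scatter) and it carries real uncertainty. Compound 4 is estimated at 750 nM (expected range 320 nM to 1700 nM).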

Compound 4, half-maximal inhibitory concentration: 720 nM
For compound 4 the middle estimate is 1.0-fold (0.02 log units) above the measured one, and the stated range covers the measured number.
By their numbers in this assay, from the lowest: compounds 2, 4, 1 and 3 (each within the scatter of the next).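

In this assay the open chain 2-(ethylamino)ethyl sits level with the ring it replaces (a 1.3-fold lower number from compound 3 to compound 4 (0.11 log units; within the scatter)) and also with the piperidin-3-yl group (a 1.2-fold higher number from compound 2 to compound 4 (0.08 log units; within the scatter)). At this place, on a saturated chain carbon bound to an oxygen on an aromatic ring, a ring is therefore not needed among these compounds, and neither the change from a ring to no ring nor the change in hydrogen-bond donors from the 1-methylpyrrolidin-3-yl group to the 2-(ethylamino)ethyl group separates the numbers beyond the scatter. Nothing among the available data offers a reason why these different groups read alike.

On these data alone, all three groups at this place still carry a nitrogen, so it remains open whether the read-out would hold with a carboxylic acid or a plain butyl chain in its stead. As far as these compounds go, it is also open whether a longer chain such as 4-(ethylamino)butyl would stay level, and whether an acetyl on the other oxygen would leave the open-chain compound as unchanged as it leaves the ring compound in the step between compound 1 and compound 3.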